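Adding a methoxy group to compound 1: cytotoxicity outlook

This account rests on a few compounds, and the source may have more. Where it says the series, first, only, none or still open, it means among the compounds named here.

Compound 1 `COc1ccc(C(=O)/C=C/c2cccc(OC)c2OC)c(O)c1` has been run in an ADME assay on RAW264.7 cells (Mus musculus) for cytotoxicity, read by MTT assay, with a stated time of 24 h, tested at 2.5 ug/mL (on this read-out lower numbers stand for a stronger effect and higher numbers for a weaker effect at the one concentration tested), where compound 1 gives 72.9%. Of the two numbers in hand it is the one that stands at the top, but only by a margin within the scatter: compound 2 `COc1ccc(OC)c(/C=C/C(=O)c2cccc(O)c2)c1` gives 72.4% in this assay, so the two values are indistinguishable and no order between them is claimed. For the measured compounds named here, no pair of measured compounds differs in one place only, so no measured step sets a scale for what a single added group does.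

Compound 3 `COc1ccc(C(=O)/C=C/c2ccc(OC)c(OC)c2OC)c(O)c1` is not yet measured. It differs from compound 1 by methoxy in place of hydrogen on an aromatic carbon. The entering group sits on an aromatic carbon of a six-membered aromatic ring of carbon only, ortho to a methoxy group, meta to a methoxy group and para to a large group. With nothing measured to point either way, the expected step from compound 1 to compound 3 in this assay is a number 0.9 percentage points lower from compound 1 to compound 3 (within the scatter), none beyond the scatter. Compound 3 is accordingly estimated at 72% in this assay, with a range from 60% to 83%.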

Compound 3, a percentage reported as activity, at one concentration (the size of the read-out at that concentration, not a potency): 96.6%
Beside the measured number, compound 3's estimate is 24.6 percentage points below it, outside the stated range (above it).
By their numbers in this assay, from the lowest: compounds 2 and 1 (each within the scatter of the next); then compound 3.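

In this assay, for the compounds shown here, methoxy in place of hydrogen on an aromatic carbon gives a number 23.7 percentage points higher from compound 1 to compound 3 (beyond the scatter) and so supplies the first single-place step, showing that one added group can shift the read-out beyond the scatter. The shift runs towards a weaker effect at the one concentration tested, so on the core of compound 1 this position, ortho to a methoxy group, meta to a methoxy group and para to a large group, is not a silent one for this read-out. The data shown establish the size and direction of this step only, and nothing at hand bears on why the number moves this way.

This single step leaves open whether the response belongs to methoxy itself or to any group at this carbon, for instance an amine, a fluorine atom or a longer ethoxy chain in the same place. It also leaves open whether the same change on another core, or at another concentration, would give a step of similar size and direction.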